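The compounds below may be only part of what the source reports. "The series", "measured", "known", "first", "only" and "open" are said of these compounds alone.

Measured so far:
compound 1, `CNC(=O)c1nc(-c2cc(OC)c(OC)c(OC)c2)n(-c2ccc(OC)cc2)n1`: 95%
compound 2, `COc1ccc(NC(=O)c2nc(-c3cc(OC)c(OC)c(OC)c3)n(-c3ccc(OC)cc3)n2)cc1`: 86%

In a functional assay on the whole organism for inhibition, with Rattus norvegicus as the target, read by paw edema, with stated times of 30 min and 3 h, at a dose of 0.28 mmol/kg by the oral route (a lower number here means less inhibition, a higher number more inhibition at the dose given (going by the name of the read-out)), compound 2 stands lowest of the two numbers; its nearest neighbour is compound 1, and the step of a number 9 percentage points lower from compound 1 to compound 2 (within the scatter) lies within the scatter, so the two compounds cannot be told apart on these numbers. Compound 3, `COc1ccc(-n2nc(C(=O)Nc3ccc(C)cc3)nc2-c2cc(OC)c(OC)c(OC)c2)cc1`, differs from compound 2 by methyl in place of methoxy on an aromatic carbon. Going by the values given here, no measured step bears on this change: the only step recorded alters the whole group on the amide-type nitrogen, not a substituent on that group, and even that step stayed within the scatter. With nothing pointing either way, compound 3 is expected to give a number close to that of compound 2, and the step of a number 4 percentage points lower from compound 2 to compound 3 (within the scatter) is estimated to remain within the scatter. The estimate for compound 3 is 82%, with a range from 65% to 95%.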

Compound 3, a percentage reported as inhibition, in the whole organism at one dose (the size of the read-out at that dose, not a potency): 77%
Compound 3: the middle estimate sits 5 percentage points above what was measured; the range from low to high includes it.
By their numbers in this assay, from the lowest: compounds 3, 2 and 1 (each within the scatter of the next, the first and the last beyond it).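

In this assay, the step at the aromatic carbon para to a large group, a number 9 percentage points lower from compound 2 to compound 3 (within the scatter), leaves methoxy and methyl at this place impossible to tell apart on these numbers, even though the change removes one hydrogen-bond acceptor. On the amide-type nitrogen, a number 18 percentage points lower from compound 1 to compound 3 (beyond the scatter) gives the first modest separation beyond the scatter, for 4-methylphenyl in place of methyl, whereas a number 9 percentage points lower from compound 1 to compound 2 (within the scatter) gave none for 4-methoxyphenyl in place of methyl. No available evidence bears on what lies behind either step.

Going by these compounds, it remains open whether a chlorine atom, a hydroxyl group, an amine or a carboxylic acid at this same place on the ring would also stay within the scatter of compound 2. Also open, on these data alone, is how an unsubstituted phenyl or a longer chain on the amide-type nitrogen would compare with the methyl of compound 1.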